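Iodo replacing ethynyl on the five-membered ring

This account rests on a few compounds, and the source may have more. Where it says the series, first, only, none or still open, it means among the compounds named here.

Measured compounds:
compound 1 `COc1ncnc2c1c(-c1cccs1)cn2[C@@H]1O[C@H](CO)[C@@H](O)[C@H]1O` — in a functional assay on CEM-DNR-bulk cells (Homo sapiens), read by MTT assay, with a stated time of 72 h (on this read-out higher numbers stand for weaker inhibition and lower numbers for stronger inhibition), compound 1 gives 12100 nM
compound 2 `C#Cc1cn([C@@H]2O[C@H](CO)[C@@H](O)[C@H]2O)c2ncnc(OC)c12` — in this assay compound 2 gives 3490 nM

For the measured compounds named here, the only step so far, a 3.5-fold lower number from compound 1 to compound 2 (0.54 log units; beyond the scatter), lowers the number. Compound 2 therefore stands lowest of the two numbers, its nearest neighbour being compound 1, separated by that same step, which lies beyond the scatter.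

Compound 3 `COc1ncnc2c1c(I)cn2[C@@H]1O[C@H](CO)[C@@H](O)[C@H]1O` is not yet measured. It differs from compound 2 as follows: iodo in place of ethynyl on an aromatic carbon. Going by the values given here, the change sits on the same aromatic carbon that was altered in the one measured step, but no measured pair exchanges ethynyl for iodo, or any halogen for anything else. Among the compounds with values here, the single step from compound 1 to compound 2 shows only that a large aromatic substituent at this carbon gives a higher number than ethynyl; it says nothing about iodo. On that basis no step beyond the scatter is expected in this assay, and compound 3 is estimated at 4000 nM, with a range of 1500 nM to 12000 nM, corresponding to an expected step of a 1.1-fold higher number from compound 2 to compound 3 (0.06 log units; within the scatter).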

Compound 3, half-maximal inhibitory concentration: > 20000 nM
Compound 3 was reported as a limit; the forecaster's own chance of this, stated with the estimate: 5%; middle value at least 5.0-fold (0.69 log units) away from the limit.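

In this assay, compound 3 is reported only as a limit, not as a number: the limit of > 20000 nM in this assay, at which 1 of the 3 values shown sits.

Even so, the change from ethynyl to iodo gives an at least 5.7-fold higher number from compound 2 to compound 3 (0.75 log units; beyond the scatter), so a higher number at this aromatic carbon is not confined to an aromatic ring substituent such as thiophen-2-yl, the only replacement for ethynyl among the earlier compounds. The other new comparison gives an at least 1.6-fold higher number from compound 1 to compound 3 (0.21 log units; that floor lies within the scatter), so iodo and thiophen-2-yl cannot be put in order, while compound 2, with ethynyl, keeps the lowest number of the three, with steps beyond the scatter to both compound 1 and compound 3.

The compounds shown leave open whether the lower number of compound 2 is tied to the triple bond of ethynyl or would also be seen with a nitrile, an amine or a short alkyl chain on the same carbon. From the compounds shown here alone, how far compound 3 lies past its limit also remains open, and with it the true size of both new steps.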